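Swapping the Triazole for a Piperidine on the Propyl Chain

A few compounds are considered here, and "the series" means these few. Any claim that something is new, unique, unknown or untested is made for them only; others in the source may bear on it.

Compound 1, `Cn1cc(C2=C(c3nn(CCCn4cncn4)c4ncccc34)C(=O)NC2=O)c2ccccc21`, gives > 100000 nM in a functional assay on SMMC-7721 cells (Homo sapiens) for antiproliferative activity, read by MTT assay, with a stated time of 48 h; a higher number here means a weaker inhibitor, a lower number a stronger inhibitor; that value is a limit of the assay, not a number.
Compound 2, `Cn1cc(C2=C(c3nn(CCCn4cncn4)c4ncccc34)C(=O)N(c3ccccc3)C2=O)c2ccccc21`, gives > 100000 nM in this assay; that value is also a limit.

Compound 1 and compound 2 share a core and differ by phenyl in place of hydrogen on an amide-type nitrogen in a ring. The step between them is a step that the two limits leave unreadable from compound 1 to compound 2. Compound 2 thus stands at the limit rather than at a number, and both values shown sit there (the limit of > 100000 nM in this assay, at which 2 of the 2 values shown sit).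

Compound 3, `Cn1cc(C2=C(c3nn(CCCN4CCCCC4)c4ncccc34)C(=O)N(c3ccccc3)C2=O)c2ccccc21`, differs from compound 2 by piperidin-1-yl in place of 1H-1,2,4-triazol-1-yl on a saturated chain carbon, three bonds along the chain from an aromatic nitrogen. Among the measured compounds shown here, no measured step touches this part of the molecule, and the one measured step that exists cannot be read in size or direction. For the measured compounds named here, the only guidance is that compound 2 sits at the limit, so a large change in this assay cannot be inferred from the data at hand. Compound 3 is therefore expected to give about 60000 nM, within a range from 10000 nM to 200000 nM. This estimate means an expected step of an at least 1.6-fold lower number from compound 2 to compound 3 (0.22 log units; that floor lies within the scatter).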

Compound 3, half-maximal inhibitory concentration: 3050 nM
Estimate against measurement, compound 3: 20-fold (1.29 log units) above; measured number outside the range, below it.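

The propyl chain proves to be a position where a change can be read in this assay: putting piperidin-1-yl in place of 1H-1,2,4-triazol-1-yl at the end of the chain gives an at least 32-fold lower number from compound 2 to compound 3 (1.51 log units; beyond the scatter). Among the compounds shown here, compound 3 is the first compound here to give a measured number rather than a limit, whereas the earlier step, on the amide-type nitrogen in a ring, cannot be read in size or direction. The true size of the new step remains unknown, and only its minimum can be stated, because compound 2 stands at a limit and not at a number: the limit of > 100000 nM in this assay, at which 2 of the 3 values shown sit.

The compounds shown leave open whether this gain belongs to the piperidine ring itself or would also appear with another amine, such as morpholine or dimethylamine, on the same propyl chain, or with a shorter or longer chain. Also open, going by these compounds, is what the phenyl on the amide-type nitrogen in a ring contributes once piperidin-1-yl is present, a question that a version of compound 3 with hydrogen in place of that phenyl would address.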